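Side-Chain Exchange on the Benzyloxy Group of Compound 3

The compounds below may be only part of what the source reports. "The series", "measured", "known", "first", "only" and "open" are said of these compounds alone.

Compound 1 `CNC(=O)[C@H]1O[C@@H](n2cnc3c(NCc4cc(Cl)cc(Cl)c4)ncnc32)[C@H](O)[C@@H]1O` — 2.5 nM
Compound 2 `CNC(=O)[C@H]1O[C@@H](n2cnc3c(NC)ncnc32)C[C@@H]1O` — 87 nM
Compound 3 `CNC(=O)[C@H]1O[C@@H](n2cnc3c(NCc4cc(Cl)ccc4OCc4ccccc4)ncnc32)[C@H](O)[C@@H]1N` — 16 nM

Of the compounds shown here, three have been measured in an assay on isolated protein for binding affinity to adenosine receptor A3 (Homo sapiens); on this read-out higher numbers stand for weaker inhibition and lower numbers for stronger inhibition. Compound 1 gives 2.5 nM, compound 2 gives 87 nM, and compound 3 gives 16 nM. Among the three numbers, compound 3 holds the second highest. Its nearest neighbour is compound 2, whose number is higher by a gap beyond the scatter; the furthest is compound 1, whose number is lower by a gap that is also beyond the scatter.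

The unmeasured compound 4 `CNC(=O)[C@H]1O[C@@H](n2cnc3c(NCc4cc(Cl)ccc4OCC(=O)N4CCNCC4)ncnc32)[C@H](O)[C@@H]1N` is derived from compound 3 by a single change: (piperazin-1-yl)carbonyl in place of phenyl on a saturated chain carbon bound to an oxygen on an aromatic ring. No step between two measured compounds addresses this kind of exchange, so nothing in the shown data tells whether a (piperazin-1-yl)carbonyl in that position helps or hurts.

In this assay compound 4 is therefore expected to land near compound 3, with a modest shift toward a higher number; the expected step is a 2.5-fold higher number from compound 3 to compound 4 (0.40 log units; beyond the scatter). The estimate for compound 4 is 40 nM, with a range from 10 nM to 200 nM.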

Compound 4, inhibition constant: 9.4 nM
Estimate against measurement, compound 4: 4.3-fold (0.63 log units) above, and the stated range ends above it.
By their numbers in this assay, from the lowest: compound 1; then compounds 4 and 3 (each within the scatter of the next); then compound 2.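

In this assay, putting (piperazin-1-yl)carbonyl in place of phenyl on a saturated chain carbon bound to an oxygen on an aromatic ring gives a 1.7-fold lower number from compound 3 to compound 4 (0.23 log units; within the scatter), so this read-out does not separate the two compounds. This place therefore accepts a very different group: the six-membered aromatic ring of carbon only leaves, and a six-membered non-aromatic ring with 2 hetero atoms enters together with a carbonyl and a hydrogen-bond donor, with no shift beyond the scatter. Compound 1, compound 2 and compound 3 could not show this, as no step among them touches this place, and no measured property is at hand to account for the result.

The compounds shown leave open which part of the entering group, the carbonyl or the piperazine ring, goes with the retained value, a question that a carboxylic acid or a (morpholin-4-yl)carbonyl group on the same chain carbon would address. Also open, as far as these compounds go, is whether a longer chain ending in the same (piperazin-1-yl)carbonyl would stay within the scatter of compound 3.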